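The compounds below may be only part of what the source reports. "The series", "measured", "known", "first", "only" and "open" are said of these compounds alone.

Compound 2 `C[C@@H]1[C@@H](N(C)C)CN1c1cc2c(cc1F)c(=O)c(C(=O)O)cn2C1CC1`: 96.3 ug/mL
Compound 3 `C[C@@H]1[C@@H](N(C)C)CN1c1c(F)cc2c(=O)c(C(=O)O)cn(C3CC3)c2c1F`: 97.1 ug/mL
Compound 1 `CNC1(C)CN(c2c(F)cc3c(=O)c(C(=O)O)cn(C4CC4)c3c2F)C1`: 0.5 ug/mL

All three compounds were tested in a physicochemical assay for solubility, at pH 7.4; a lower number here means a less soluble compound, a higher number a more soluble compound. Compound 2 gives 96.3 ug/mL, the second highest of the three numbers. Its nearest neighbour is compound 3, reached by fluoro in place of hydrogen on an aromatic carbon, with a step of a 1.0-fold higher number from compound 2 to compound 3 (0.00 log units; within the scatter). The furthest is compound 1, which in this assay gives 0.5 ug/mL.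

Compound 4 `CNC1(C)CN(c2cc3c(cc2F)c(=O)c(C(=O)O)cn3C2CC2)C1` has not yet been measured. It differs from compound 2 by a group of 7 heavy atoms (5 carbon, 2 nitrogen; one four-membered non-aromatic ring with 1 hetero atom) in place of a group of 8 heavy atoms (6 carbon, 2 nitrogen; one four-membered non-aromatic ring with 1 hetero atom), on an aromatic carbon. Among the compounds with values here, one measured step bears directly on this: compound 1 and compound 3 differ by the same pair of groups, and the step from one to the other was a 190-fold higher number from compound 1 to compound 3 (2.29 log units; beyond the scatter), a large change. Compound 4 stands to compound 2 as compound 1 stands to compound 3, so a large drop in solubility is expected, a 160-fold lower number from compound 2 to compound 4 (2.21 log units; beyond the scatter). Compound 4 is therefore estimated at 0.6 ug/mL, with a range from 0.2 ug/mL to 3 ug/mL.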

Compound 4, solubility: 0.7 ug/mL
Compound 4: middle estimate off by 1.2-fold (0.07 log units), on the low side; the range from low to high includes it.
By their numbers in this assay, from the lowest: compounds 1 and 4 (each within the scatter of the next); then compounds 2 and 3 (each within the scatter of the next).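

In this assay, placing 3-methyl-3-(methylamino)azetidin-1-yl on this aromatic carbon gives a 140-fold lower number from compound 2 to compound 4 (2.14 log units; beyond the scatter), so the large drop seen earlier with the fluoro group present also appears on the core without it. The fluoro group itself stays within the scatter with this azetidine, at a 1.4-fold higher number from compound 1 to compound 4 (0.15 log units; within the scatter), as it did with the other group, and the swap of groups therefore accounts for the large steps among these compounds. No measurement here explains why the swap has so large an effect.

The two groups differ in several features at once, so the compounds shown cannot tell which of them goes with the drop. On these data alone, how a piperazine ring, or a plain amino group on the azetidine, would behave at this carbon also remains open.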